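This account rests on a few compounds, and the source may have more. Where it says the series, first, only, none or still open, it means among the compounds named here.

Three compounds of the series carry numbers in a functional assay on the whole organism (Tail, strain ICR) with Mus musculus as the target, in the tail flick test, with a stated time of 60 min, at a dose of 25 umol/kg by the oral route; a lower number here means a weaker effect, a higher number a stronger effect of the compound at the dose given. Compound 1 `O=C(CN(c1nc(Cl)nc2[nH]cnc12)C1CC1)N[C@@H](CO)C(=O)OCc1ccccc1` gives 34.2%, compound 2 `O=C(CN(c1nc(Cl)nc2[nH]cnc12)C1CC1)NCC(=O)OCc1ccccc1` gives 41.9%, and compound 3 `N=C(N)NCCC[C@H](NC(=O)CN(c1nc(Cl)nc2[nH]cnc12)C1CC1)C(=O)OCc1ccccc1` gives 30.6%. Compound 3 holds the lowest of the three numbers, with compound 1 nearest and within the scatter; the only gap beyond the scatter is a number 11.3 percentage points lower from compound 2 to compound 3 (beyond the scatter).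

Compound 4 `O=C(CN(c1nc(Cl)nc2[nH]cnc12)C1CC1)N[C@@H](CC(=O)OCc1ccccc1)C(=O)OCc1ccccc1` has not been measured in this assay. Against compound 3 it carries a group of 10 heavy atoms (8 carbon, 2 oxygen; one six-membered aromatic ring of carbon only) in place of a group of 6 heavy atoms (3 carbon, 3 nitrogen; no ring), on a saturated chain carbon, two bonds along the chain from an amide-type nitrogen and a carbonyl carbon.

Going by the values given here, two measured steps bear on this change. At the same place on the chain the record shows a number 3.6 percentage points lower from compound 1 to compound 3 (within the scatter), a move that stayed within the scatter. The other step, a number 11.3 percentage points lower from compound 2 to compound 3 (beyond the scatter), was a modest move beyond the scatter. Both show that what is attached along this chain shifts the read-out little, and compound 4 only exchanges one group there for another. No step beyond the scatter is therefore expected in this assay in either direction, though a small upward drift is plausible given 34.2% for compound 1 and 41.9% for compound 2.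

Compound 4 is estimated at 35%, with a range from 22% to 48%. The expected step is a number 4.4 percentage points higher from compound 3 to compound 4 (within the scatter).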

Compound 4, a percentage reported as activity, at one dose (the size of the read-out at that dose, not a potency): 22.4%
Compound 4: the middle estimate sits 12.6 percentage points above what was measured; measured number inside the range.
By their numbers in this assay, from the lowest: compounds 4, 3, 1 and 2 (each within the scatter of the next, the first and the last beyond it).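

Going by these compounds alone, at this place on the chain, a number 11.8 percentage points lower from compound 1 to compound 4 (beyond the scatter) is the first step in this assay to pass the scatter, whereas the earlier exchange of hydroxy for the group of 6 heavy atoms did not, so the group carried here can separate two compounds. Set against the unsubstituted chain carbon of compound 2, (benzyloxycarbonyl)methyl gives a number 19.5 percentage points lower from compound 2 to compound 4 (beyond the scatter), a wider gap than the one printed for compound 3, while the direct exchange of the group of 6 heavy atoms for benzyloxycarbonyl, a number 8.2 percentage points lower from compound 3 to compound 4 (within the scatter), does not separate those two compounds. No measurement on hand accounts for any of these steps.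

The compounds shown leave open whether the read-out at this place depends on the benzyl ester as such, which a free carboxylic acid in place of benzyloxycarbonyl would test. They also leave open whether a longer chain carrying the same benzyloxycarbonyl, or a simple amine at the end of such a chain, would stay with compound 4 or move towards compound 2 in this assay.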